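Fluoro for Methyl on the Aryl Ring of Compound 2

The source may report more compounds than this note shows. Statements on the series, on what has been measured and on what is new or still open speak of the compounds shown alone.

Of the compounds shown here, two have been measured so far, compound 1 `COc1cc2c(Oc3ccc(NC(=O)c4nccc(-c5ccc(F)cc5)n4)cc3F)ccnc2cc1OCCCN1CCCCC1` and compound 2 `COc1cc2c(Oc3ccc(NC(=O)c4nccc(-c5ccc(C)cc5)n4)cc3F)ccnc2cc1OCCCN1CCCC1`. In a functional assay on NCI-H460 cells (Homo sapiens) for cytotoxicity, read by MTT assay, with a stated time of 72 h (on this read-out lower numbers stand for stronger inhibition and higher numbers for weaker inhibition), compound 1 gives 240 nM, and compound 2 gives 440 nM. Among the measured compounds shown here, compound 2 thus holds the higher of the two numbers, yet its only neighbour, compound 1, lies within the usual scatter of it, so no order between the two can be read. Compound 3 `COc1cc2c(Oc3ccc(NC(=O)c4nccc(-c5ccc(F)cc5)n4)cc3F)ccnc2cc1OCCCN1CCCC1` is not yet measured. It differs from compound 2 by fluoro in place of methyl on an aromatic carbon; cut one bond further out, the change reads 4-methylphenyl to 4-fluorophenyl. For the measured compounds named here, no pair of measured compounds isolates this change, so the expectation rests on the two numbers alone. The step of a 1.4-fold lower number from compound 2 to compound 3 (0.14 log units; within the scatter) is expected to stay within the scatter, at most a slight move toward a lower number. Compound 3 is therefore estimated at 320 nM in this assay, with a range from 130 nM to 800 nM.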

Compound 3, half-maximal inhibitory concentration: 300 nM
The estimate for compound 3 lay 1.1-fold (0.03 log units) above the measured number; measured number inside the range.
By their numbers in this assay, from the lowest: compounds 1, 3 and 2 (each within the scatter of the next).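

In this assay the change from 4-methylphenyl to 4-fluorophenyl now stands as a clean pair: fluoro in place of methyl on an aromatic carbon, para to a large group, gives a 1.5-fold lower number from compound 2 to compound 3 (0.17 log units; within the scatter) and this step lies within the scatter, so the two groups cannot be told apart at this position. The other end of the molecule now has a pair of its own: with the 4-fluorophenyl held fixed, pyrrolidin-1-yl in place of piperidin-1-yl on the saturated chain carbon gives a 1.3-fold higher number from compound 1 to compound 3 (0.10 log units; within the scatter) and this step also lies within the scatter, so neither change separates the compounds. No evidence at hand bears on these two steps.

Going by these compounds, whether a nitrile or a methoxy group on the aryl ring would move the number beyond the scatter stays open. The same holds for a morpholine or a dimethylamino group at the end of the chain.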